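Swapping a urea for an amide in compound 1

A few compounds are considered here, and "the series" means these few. Any claim that something is new, unique, unknown or untested is made for them only; others in the source may bear on it.

Compound 1 `COc1cc(-c2nn(-c3ccc(NC(=O)Nc4ccc(Cl)c(C(F)(F)F)c4)cc3)cc2-c2ccncc2)ccc1Cl` is the reference point here. In a functional assay on M14 cells (Homo sapiens) for antiproliferative activity, read by sulforhodamine B assay, with a stated time of 48 h (on this read-out higher numbers stand for weaker inhibition and lower numbers for stronger inhibition), compound 1 gives 1740 nM, the lowest number among the three measured compounds. Compound 2 `COc1cc(-c2nn(-c3ccc(NC(=O)Nc4cc(C(F)(F)F)cc(C(F)(F)F)c4)cc3)cc2-c2ccncc2)ccc1Cl` gives 1990 nM in this assay, which sits within the scatter of compound 1. For the measured compounds named here, compound 3 `COc1cc(-c2nn(-c3ccc(NC(=O)c4ccc(Cl)c(Cl)c4)cc3)cc2-c2ccncc2)ccc1Cl` gives 22400 nM in this assay, and the change a 13-fold higher number from compound 1 to compound 3 (1.11 log units; beyond the scatter) is the only measured step that bears on the question at hand.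

Compound 4 `COc1cc(-c2nn(-c3ccc(NC(=O)c4cc(Cl)cc(Cl)c4)cc3)cc2-c2ccncc2)ccc1Cl` has not yet been measured in this assay. It differs from compound 1 in one place: 3,5-dichlorophenyl in place of (4-chloro-3-(trifluoromethyl)phenyl)amino on a carbonyl carbon. This is the same kind of change as the step from compound 1 to compound 3, with the two chlorines set on the new ring at the 3,5-positions instead of the 3,4-positions. Because the measured step of a 13-fold higher number from compound 1 to compound 3 (1.11 log units; beyond the scatter) was large and towards weaker inhibition, a step of similar size and direction is expected, an 11-fold higher number from compound 1 to compound 4 (1.06 log units; beyond the scatter). Compound 4 is therefore estimated at 20000 nM in this assay, with a range from 7000 nM to 60000 nM.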

Compound 4, half-maximal inhibitory concentration: 7390 nM
The estimate for compound 4 lay 2.7-fold (0.43 log units) above the measured number, and the stated range covers the measured number.
By their numbers in this assay, from the lowest: compounds 1 and 2 (each within the scatter of the next); then compound 4; then compound 3.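

With the 3,5-dichlorophenyl group, the amide still inhibits less well than the urea in this assay, showing a 4.2-fold higher number from compound 1 to compound 4 (0.63 log units; beyond the scatter) for this change. What is new is that the size of this loss depends on the ring on the carbonyl carbon: moving to the 3,5-dichlorophenyl group gives a 3.0-fold lower number from compound 3 to compound 4 (0.48 log units; beyond the scatter) even though the two amides differ only in where their chlorines sit. Chlorine placement therefore matters here, although compound 4 remains the weaker compound next to compound 1.

From the compounds shown here alone, it remains open whether a nitrile or a carboxylic acid on this amide ring would bring the number closer to that of compound 1. No evidence is available to explain either step.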